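From Benzyl Ether to Benzamide on the Saturated Ring Carbon

The compounds below may be only part of what the source reports. "The series", "measured", "known", "first", "only" and "open" are said of these compounds alone.

Of the compounds shown here, three built on one shared core have been measured in a functional assay on HEK293 cells for agonist activity at G-protein coupled receptor 39 (Homo sapiens), read by scintillation proximity assay and inositol phosphate accumulation, with a stated time of 75 min; on this read-out lower numbers stand for an effect already at smaller amounts and higher numbers for an effect only at larger amounts of compound. Compound 1 `Cc1nn(-c2ncnc3nc[nH]c23)c2c1C(c1ccc(F)cc1Cl)CC(=O)N2` carries a 2-chloro-4-fluorophenyl group on a saturated ring carbon, and compound 1 gives 280 nM. Compound 2 `Cc1nn(-c2ncnc3nc[nH]c23)c2c1C(OCc1ccccc1Cl)CC(=O)N2` carries a (2-chlorobenzyl)oxy group at that place, and compound 2 gives 47 nM. Compound 3 `Cc1nn(-c2ncnc3nc[nH]c23)c2c1C(OCc1ccccc1F)CC(=O)N2` carries a (2-fluorobenzyl)oxy group there, and compound 3 gives 78 nM. Among these three numbers compound 3 stands second highest: its nearest neighbour is compound 2, as a 1.7-fold higher number from compound 2 to compound 3 (0.22 log units; within the scatter) shows, and its furthest is compound 1, from which a 3.6-fold lower number from compound 1 to compound 3 (0.56 log units; beyond the scatter) separates it.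

Compound 4 `Cc1nn(-c2ncnc3nc[nH]c23)c2c1C(NC(=O)c1ccccc1)CC(=O)N2` differs from compound 3 in one place: benzamido in place of (2-fluorobenzyl)oxy on a saturated ring carbon. For the measured compounds named here, no measured step exchanges an ether link for an amide link, so the closest guides are the two steps that replace the group on this saturated ring carbon, a 6.0-fold lower number from compound 1 to compound 2 (0.78 log units; beyond the scatter) and a 3.6-fold lower number from compound 1 to compound 3 (0.56 log units; beyond the scatter), both modest and both toward lower numbers. A shift of similar, modest size is therefore expected, but its direction is open, and the untested linkage calls for a wide range. The expected step is a 1.9-fold higher number from compound 3 to compound 4 (0.28 log units; within the scatter). Compound 4 is estimated to give 150 nM, within a range from 40 nM to 600 nM.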

Compound 4, half-maximal effective concentration: 158 nM
Compound 4: the middle estimate sits 1.1-fold (0.02 log units) below what was measured, and the stated range covers the measured number.
By their numbers in this assay, from the lowest: compounds 2 and 3 (each within the scatter of the next); then compounds 4 and 1 (each within the scatter of the next).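

In this assay, an amide link on this saturated ring carbon gives a higher number than either ether link, with a 2.0-fold higher number from compound 3 to compound 4 (0.31 log units; beyond the scatter) and a 3.4-fold higher number from compound 2 to compound 4 (0.53 log units; beyond the scatter) both beyond the scatter, so the two benzyl ethers remain the compounds with the lowest numbers here. Set against the 2-chloro-4-fluorophenyl group, the benzamido group cannot be told apart, since a 1.8-fold lower number from compound 1 to compound 4 (0.25 log units; within the scatter) stays within the scatter, which shows that this position accepts an amide link without a readable change from the aryl compound. The benzamido group differs from the ether groups in both its link and its ring, as it brings a hydrogen-bond donor and has no halogen. Nothing available here separates these changes or explains the higher number.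

The compounds shown leave open whether a 2-chlorobenzamido or 2-fluorobenzamido group, which would restore the halogen while keeping the amide link, would bring the number closer to those of the ethers. They also leave open how a benzylamino group, with an amine as the link, or a longer chain between the amide and the ring would behave at this position.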